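The source may hold more compounds than are shown below. What is called first, only, known or untested is meant among the compounds shown, and "the series" means these compounds.

Measured so far:
compound 1, `COc1ncnc2c1c(-c1ccsc1)cn2[C@@H]1O[C@H](CO)[C@@H](O)[C@H]1O`: 3350 nM
compound 2, `CNc1ncnc2c1c(-c1ccccc1)cn2[C@@H]1O[C@H](CO)[C@@H](O)[C@H]1O`: > 20000 nM

In a functional assay on HeLa S3 cells (Homo sapiens) for antiproliferative activity, read by XTT assay, with a stated time of 72 h (on this read-out higher numbers stand for weaker inhibition and lower numbers for stronger inhibition), compound 1 gives 3350 nM. In this assay compound 2 gives only a limit, > 20000 nM, which is the limit of > 20000 nM in this assay, at which 1 of the 2 values shown sits. Compound 2 therefore stands at the weaker end of the two numbers shown, with no measured value of its own; compound 1, which differs from it in more than one place, is the only compound here with a number.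

Compound 3, `CNc1ncnc2c1c(-c1ccsc1)cn2[C@@H]1O[C@H](CO)[C@@H](O)[C@H]1O`, is not yet measured in this assay. It differs from compound 2 in one place, (thiophen-3-yl in place of phenyl on an aromatic carbon). For the measured compounds named here, no step between measured compounds is available to size this change. The thiophen-3-yl group is shared with compound 1, which gives 3350 nM, so the expected step of an at least 1.6-fold lower number from compound 2 to compound 3 (0.22 log units; that floor lies within the scatter) is a modest one toward lower numbers. Compound 3 is estimated at 12000 nM, within a range from 3000 nM to 40000 nM.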

Compound 3, half-maximal inhibitory concentration: > 20000 nM
Compound 3 was reported as a limit; the forecaster's own chance of this, stated with the estimate: 45%; middle value at least 1.6-fold (0.22 log units) from the limit.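

Methylamino in place of methoxy on an aromatic carbon, with thiophen-3-yl kept, gives the first readable step among these compounds: in this assay there is an at least 5.9-fold higher number from compound 1 to compound 3 (0.77 log units; beyond the scatter). The thiophen-3-yl group alone therefore does not ensure a measured value, as the read-out for compound 3 is only a limit when methylamino replaces methoxy. The effect of thiophen-3-yl in place of phenyl cannot be read, because compound 2 and compound 3 both stand at the same limit: the limit of > 20000 nM in this assay, at which 2 of the 3 values shown sit.

The compounds shown leave open how phenyl behaves alongside methoxy, which could size that exchange with measured numbers on both sides. They also leave open whether an unsubstituted amino group, dimethylamino or ethoxy in place of methoxy would give a value near that of compound 1 or reach the limit.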